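A few compounds are considered here, and "the series" means these few. Any claim that something is new, unique, unknown or untested is made for them only; others in the source may bear on it.

Compound 1 `COc1ccc(Nc2c(-c3ccc4[nH]nc(C)c4c3)nc3cnc(N4CCN(C)CC4)cn23)cc1` was taken into a functional assay on MV4-11 cells (Homo sapiens) for inhibition, with a stated time of 120 h (on this read-out higher numbers stand for weaker inhibition and lower numbers for stronger inhibition), where the entry for compound 1 reads "not determined" (no result reported), so it stands without a number. Going by the values given here, compound 2 `Cc1n[nH]c2ccc(-c3nc4cnc(N5CCN(C)CC5)cn4c3Nc3ccc(Cl)cc3F)cc12` is therefore the only compound with a figure: in this assay compound 2 gives 10400 nM, the sole number to hand, beside one further entry that carries no value. Compound 3 `Cc1n[nH]c2ccc(-c3nc4cnc(N5CCN(C)CC5)cn4c3Nc3ccc(Br)cc3Cl)cc12` has not yet been measured. It differs from compound 2 in one place: 4-bromo-2-chlorophenyl in place of 4-chloro-2-fluorophenyl on a nitrogen on an aromatic ring. Among the compounds with values here, no step between two measured compounds is available, so there is nothing to set the size of this change against. For compound 3 in this assay a step of a 1.2-fold lower number from compound 2 to compound 3 (0.06 log units; within the scatter) is expected, which amounts to none beyond the usual scatter. On that basis compound 3 is estimated at 9000 nM, within a range from 3000 nM to 30000 nM.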

Compound 3, half-maximal inhibitory concentration: 9220 nM
The estimate for compound 3 lay 1.0-fold (0.01 log units) below the measured number, and the stated range covers the measured number.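

In this assay, going by these compounds alone, putting 4-bromo-2-chlorophenyl in place of 4-chloro-2-fluorophenyl on a nitrogen on an aromatic ring gives a 1.1-fold lower number from compound 2 to compound 3 (0.05 log units; within the scatter), the first step that can be read at this position. Both halogens of the ring are exchanged in this one change, yet the read-out does not move beyond the scatter, so compound 2 and compound 3 stand level. Nothing available bears on why this exchange leaves the number where it is.

The compounds shown leave open whether a phenyl ring carrying an amine or a carboxylic acid, or a longer alkyl chain in place of the ring, would shift the number beyond the scatter. They also leave open whether any change elsewhere on the shared core would do so.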